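The source may hold more compounds than are shown below. What is called first, only, known or untested is meant among the compounds shown, and "the series" means these compounds.

Among the compounds with values here, compound 1 `CCCCOc1ccc(-c2nc3ncccn3c2Nc2ccccc2)cc1` is the only compound with a number in a toxicity assay on A549 cells (Homo sapiens) for cytotoxicity, read by luminescence and CellTiter-Glo, with a stated time of 48 h; a lower number here means that less compound is tolerated, a higher number that more compound is tolerated: compound 1 gives 100000 nM. Compound 2 `CCCCOc1ccc(-c2nc3ncccn3c2NCc2c[nH]cn2)cc1` shows in this assay only a limit, > 100000 nM. The step of a number no lower from compound 1 to compound 2 (the limit leaves the size open) is therefore open in size because the limit of > 100000 nM in this assay, at which 1 of the 2 values shown sits, is all that compound 2 shows. Compound 3 `COCCOc1ccc(-c2nc3ncccn3c2Nc2ccccc2)cc1` differs from compound 1 by methoxy in place of ethyl on a saturated chain carbon, two bonds along the chain from an oxygen on an aromatic ring. Within the data shown here, no measured step touches this part of the molecule, so nothing speaks for a change beyond the scatter. The expected step of no change at the digits printed from compound 1 to compound 3 (within the scatter) is none beyond the scatter, and compound 3 is estimated at 100000 nM, ranging from 50000 nM to 200000 nM.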

Compound 3, half-maximal cytotoxic concentration: > 100000 nM
Compound 3: a limit, no number (the forecaster's own chance of this, stated with the estimate: 45%); the middle value sits exactly at the limit.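

Replacing butoxy with 2-methoxyethoxy is the only change shown on this chain, and in this assay it gives a number no lower from compound 1 to compound 3 (the limit leaves the size open). Placing methoxy on this chain therefore brings no sign that less compound is tolerated. The size of the step cannot be read, because all that compound 3 shows is this: the limit of > 100000 nM in this assay, at which 2 of the 3 values shown sit.

Going by these compounds, how far compound 3 lies beyond its limit stays open. So does what an amine or a carboxylic acid at the end of this chain would do in this assay.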